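The source may report more compounds than this note shows. Statements on the series, on what has been measured and on what is new or still open speak of the compounds shown alone.

Measured in a functional assay on MDA-MB-468 cells (Homo sapiens) for antiproliferative activity, read by WST assay, with a stated time of 3 days; a higher number here means a weaker inhibitor, a lower number a stronger inhibitor:
compound 1 `O=c1cc(I)n([C@@H]2O[C@H](CO)[C@@H](O)[C@H]2O)c(=O)[nH]1`: > 50000 nM (a limit)
compound 2 `Nc1cc(=O)[nH]c(=O)n1[C@@H]1O[C@H](CO)[C@@H](O)[C@H]1O`: > 50000 nM (a limit)

Compound 2 gives no number, only the limit > 50000 nM. Compound 1 offers no firmer reference, since both measured compounds stand at one limit: the limit of > 50000 nM in this assay, at which 2 of the 2 values shown sit. Going by the values given here, the single measured step is a step that the two limits leave unreadable from compound 1 to compound 2, and it provides no size to carry forward.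

Compound 3 `O=c1cc(NO)n([C@@H]2O[C@H](CO)[C@@H](O)[C@H]2O)c(=O)[nH]1` follows from compound 2 by hydroxy in place of hydrogen on a nitrogen on an aromatic ring. In words, this is hydroxy in place of hydrogen on a nitrogen on an aromatic ring, or amino to hydroxyamino. Among the compounds with values here, no measured step involves this change, so the expectation rests on very little.

Since compound 2 sits at the limit > 50000 nM, any readable result for compound 3 would mark a stronger inhibitor in this assay. A further limit remains the likeliest single outcome, with a modest gain in strength as the alternative. The expected step is an at least 1.6-fold lower number from compound 2 to compound 3 (0.22 log units; that floor lies within the scatter). Compound 3 is estimated at 30000 nM, with an expected range from 6000 nM to 50000 nM.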

Compound 3, half-maximal inhibitory concentration: > 50000 nM
Compound 3: no number, only a limit (the forecaster's own chance of this, stated with the estimate: 60%); middle value at least 1.6-fold (0.22 log units) away from the limit.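

In this assay compound 3 gives > 50000 nM, a limit, so no new step can be read from compound 1 or compound 2 to compound 3: the limit of > 50000 nM in this assay, at which 3 of the 3 values shown sit.

The compounds shown leave open whether any group in this place on the shared core gives a readable number in this assay, and how iodo, amino and hydroxyamino rank against one another.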